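Benzyl Variant With Added Methyl: Expected Potency

The compounds below may be only part of what the source reports. "The series", "measured", "known", "first", "only" and "open" are said of these compounds alone.

Measured compounds:
Compound 1 `COc1cc(-c2nc3cc(/C=C4\SC(=O)NC4=O)ccc3[nH]2)cc(OC)c1OC` gives 6830 nM in a functional assay on MDA-MB-231 cells (Homo sapiens) for inhibition, read by MTT assay, with a stated time of 48 h; on this read-out lower numbers stand for stronger inhibition and higher numbers for weaker inhibition.
Compound 2 `COc1cc(-c2nc3cc(/C=C4\SC(=O)N(CC(=O)N5CCCC5)C4=O)ccc3[nH]2)cc(OC)c1OC` gives 2880 nM in this assay.
Compound 3 `COc1cc(-c2nc3cc(/C=C4\SC(=O)N(Cc5ccccc5)C4=O)ccc3[nH]2)cc(OC)c1OC` gives 2290 nM in this assay.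

Compound 3 has the lowest number of the three in this assay; its gap to compound 2 is within the scatter, so the two cannot be ordered, while its gap to compound 1 is beyond the scatter. The measured steps show that substitution on the ring amide-type nitrogen lowers the number modestly: a 2.4-fold lower number from compound 1 to compound 2 (0.38 log units; beyond the scatter) and a 3.0-fold lower number from compound 1 to compound 3 (0.47 log units; beyond the scatter). The comparison a 1.3-fold lower number from compound 2 to compound 3 (0.10 log units; within the scatter) falls within the scatter.

Compound 4 `COc1cc(-c2nc3cc(/C=C4\SC(=O)N(Cc5cccc(C)c5)C4=O)ccc3[nH]2)cc(OC)c1OC` differs from compound 3 by methyl in place of hydrogen on an aromatic carbon. Going by the values given here, no measured step touches the benzyl ring itself, so there is no direct precedent for this change. Given that the swap from the pyrrolidinyl-carbonyl group to the phenyl ring gave only a 1.3-fold lower number from compound 2 to compound 3 (0.10 log units; within the scatter), a small addition to the phenyl ring is expected to produce little movement: a 1.1-fold lower number from compound 3 to compound 4 (0.06 log units; within the scatter) is the estimated step, essentially within the scatter. Compound 4 is therefore expected at about 2000 nM, with a range from 900 nM to 4500 nM.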

Compound 4, half-maximal inhibitory concentration: 3260 nM
Beside the measured number, compound 4's estimate is 1.6-fold (0.21 log units) below it, within the range that was stated.
By their numbers in this assay, from the lowest: compounds 3, 2 and 4 (each within the scatter of the next); then compound 1.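

In this assay, the only change shown on the benzyl ring itself, methyl in place of hydrogen on an aromatic carbon, gives a 1.4-fold higher number from compound 3 to compound 4 (0.15 log units; within the scatter) and so cannot be told apart from no change. Compound 4 also cannot be separated from the compound bearing the (pyrrolidin-1-yl)carbonyl group, with a 1.1-fold higher number from compound 2 to compound 4 (0.05 log units; within the scatter) on that comparison. The lower number that substitution on the amide-type nitrogen gave over hydrogen persists with 3-methylbenzyl, as a 2.1-fold lower number from compound 1 to compound 4 (0.32 log units; beyond the scatter) shows, and no available measurement offers a cause for these numbers.

From the compounds shown here alone, whether a larger group at this aromatic carbon, such as an amine or a carboxylic acid, would move the number beyond the scatter remains open. Also open, going by these compounds, is whether a longer chain between the amide-type nitrogen and the phenyl ring would do so.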